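The source may report more compounds than this note shows. Statements on the series, on what has been measured and on what is new or still open speak of the compounds shown alone.

Measured so far:
- compound 1 `CCc1nc2nc(C(F)(F)F)ccc2c(=O)n1Cc1cn(CCC(F)(F)C(F)(F)C(F)(F)C(F)(F)C(F)(F)C(F)(F)F)nn1` gives 2830 nM
- compound 2 `O=C(Cn1cc(COc2nc(-c3ccccc3)nc3nc(C(F)(F)F)ccc23)nn1)Nc1ccccc1` gives 650 nM

In a functional assay on MDA-MB-231 cells (Homo sapiens) for antiproliferative activity, read by sulforhodamine B assay, with a stated time of 48 h (a higher number here means a weaker inhibitor of growth, a lower number a stronger inhibitor of growth), compound 2 gives 650 nM, the lower of the two numbers, and the gap to compound 1 lies beyond the scatter. Compound 3 `CCCCCCCCn1cc(COc2nc(-c3ccccc3)nc3nc(C(F)(F)F)ccc23)nn1` keeps the rest of compound 2, with one change: heptyl in place of phenylcarbamoyl on a saturated chain carbon bound to an aromatic nitrogen. Within the data shown here, no measured pair isolates this change, so the expectation is weakly grounded. Compound 1, which also ends in a saturated chain but has a different core, gives 2830 nM, so a moderate rise in this assay is expected. The expected step is a 1.8-fold higher number from compound 2 to compound 3 (0.27 log units; within the scatter). For compound 3 the estimated value is 1200 nM, with an expected range of 350 nM to 4500 nM.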

Compound 3, concentration for 50% growth inhibition: 570 nM
Beside the measured number, compound 3's estimate is 2.1-fold (0.32 log units) above it; the measured number falls inside the stated range.
By their numbers in this assay, from the lowest: compounds 3 and 2 (each within the scatter of the next); then compound 1.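

In this assay the exchange of phenylcarbamoyl for heptyl on a saturated chain carbon bound to an aromatic nitrogen gives a step within the scatter (a 1.1-fold lower number from compound 2 to compound 3 (0.06 log units; within the scatter)). At this position on the shared core, this level of growth inhibition therefore does not depend on the aromatic ring, the hydrogen-bond donor or the hydrogen-bond acceptor of phenylcarbamoyl. An aromatic amide and a plain alkyl chain are interchangeable here, at least for this pair.

As far as these compounds go, whether a longer chain, an amine or a carboxylic acid in place of heptyl would hold this level remains open. No measurement on these compounds offers an explanation for this tolerance.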